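Ring nitrogen substituent in a pair of curcuminoid-type analogues

This account rests on a few compounds, and the source may have more. Where it says the series, first, only, none or still open, it means among the compounds named here.

Compound 1 `CN1C/C(=C\c2cccnc2)C(=O)/C(=C/c2ccccc2F)C1` is the reference point here. Within the data shown here, in a functional assay on HepG2 cells (Homo sapiens) for cytotoxicity, read by MTT assay, with a stated time of 24 h (a higher number here means a weaker inhibitor, a lower number a stronger inhibitor), compound 1 gives 4810 nM, the highest of the two numbers so far; its nearest neighbour, compound 2 `CN1C/C(=C\c2cccnc2)C(=O)/C(=C/c2ccccc2C(F)(F)F)C1`, gives 2550 nM in this assay, and the move a 1.9-fold lower number from compound 1 to compound 2 (0.28 log units; within the scatter) stays within the scatter. Compound 3 `O=C1/C(=C/c2cccnc2)CN(S(=O)(=O)c2ccccc2)C/C1=C\c1ccccc1F` has not yet been measured. It differs from compound 1 as follows: phenylsulfonyl in place of methyl on an amine nitrogen in a ring. Among the measured compounds shown here, no measured step touches the amine nitrogen in the ring; the only step available concerns the fluoro to trifluoromethyl exchange on the aromatic carbon and was itself within the scatter, so nothing in the present numbers points to a direction for this change. The expectation is therefore a step of a 1.2-fold lower number from compound 1 to compound 3 (0.08 log units; within the scatter) in this assay, that is, no step beyond the scatter. Compound 3 is expected to give about 4000 nM in this assay, within 1200 nM to 15000 nM.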

Compound 3, half-maximal inhibitory concentration: 8210 nM
For compound 3 the middle estimate is 2.1-fold (0.31 log units) below the measured one; the measured number falls inside the stated range.
By their numbers in this assay, from the lowest: compounds 2, 1 and 3 (each within the scatter of the next, the first and the last beyond it).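

In this assay, among these compounds, the step at the amine nitrogen in a ring gives a 1.7-fold higher number from compound 1 to compound 3 (0.23 log units; within the scatter), so this is the first reading at this position, and it stays within the scatter. Phenylsulfonyl brings nine heavy atoms, a six-membered aromatic ring and two hydrogen-bond acceptors in place of a single methyl carbon, yet the change does not separate compound 3 from compound 1 in this assay. No measurement on these compounds bears on why the number responds so little to this exchange.

The compounds shown leave open whether a smaller or differently linked group on this nitrogen, such as acetyl, benzyl or a bare hydrogen, would produce a step beyond the scatter. They also leave open whether phenylsulfonyl gives a similar step when the aromatic fluoro is replaced by trifluoromethyl.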